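The compounds below may be only part of what the source reports. "The series", "measured", "known", "first", "only" and "open" are said of these compounds alone.

For the measured compounds named here, in a functional assay on Huh-7 cells (Homo sapiens) for cytotoxicity, read by MTT assay, with a stated time of 3 days (on this read-out lower numbers stand for higher toxicity in this test and higher numbers for lower toxicity in this test), compound 1 (`O=C1CCCN1Cc1ncnc2c1ncn2[C@@H]1O[C@H](CO)[C@@H](O)[C@H]1O`) gives 45000 nM and compound 2 (`OC[C@H]1O[C@@H](n2cnc3c(CN4CCCCC4)ncnc32)[C@H](O)[C@@H]1O`) gives 87000 nM on the same read-out, so compound 2 stands within the scatter of the only other measured compound. Compound 3 (`OC[C@H]1O[C@@H](n2cnc3c(CSc4ccccc4)ncnc32)[C@H](O)[C@@H]1O`) keeps the shared core and carries phenylsulfanyl in place of piperidin-1-yl on a saturated chain carbon bound to an aromatic carbon. Going by the values given here, one measured step bears on this place, a 1.9-fold higher number from compound 1 to compound 2 (0.29 log units; within the scatter) for piperidin-1-yl in place of 2-oxopyrrolidin-1-yl, and it stayed within the scatter. It is a single step with a different entering group, so it guides only weakly. On these data alone, no step beyond the scatter is therefore expected in this assay and the direction remains open. A step of a 1.5-fold lower number from compound 2 to compound 3 (0.16 log units; within the scatter) is the estimate, placing the expected value among the two measured ones. For compound 3 the estimate is 60000 nM with 20000 nM to 150000 nM as the expected range.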

Compound 3, half-maximal cytotoxic concentration: > 100000 nM
Compound 3 gave a limit, no number; the forecaster's own chance of this, stated with the estimate: 20%; middle value at least 1.6-fold (0.22 log units) from the limit.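

In this assay compound 3 gives > 100000 nM, which is a limit of the assay and not a number. Phenylsulfanyl in place of 2-oxopyrrolidin-1-yl on a saturated chain carbon bound to an aromatic carbon gives an at least 2.2-fold higher number from compound 1 to compound 3 (0.34 log units; beyond the scatter), the first step at this place to pass the scatter, and it points towards lower toxicity in this test. Against piperidin-1-yl the same group gives an at least 1.1-fold higher number from compound 2 to compound 3 (0.06 log units; that floor lies within the scatter), so only a floor can be read for that step, and it does not set compound 3 apart from compound 2.

On these data alone, how far past the limit compound 3 lies stays open, and with it the true size of both steps. Also open, as far as these compounds go, is whether phenoxy or an open-chain amine such as dimethylamino in the same place would give a number like those of compound 2 or compound 3.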